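Removing the Chloro Group of Compound 1: An Expectation

The source may report more compounds than this note shows. Statements on the series, on what has been measured and on what is new or still open speak of the compounds shown alone.

Compound 1 `O=C(Nc1nc2ccc(F)cc2s1)N1CCN(c2ccc(Cl)nn2)CC1` in an assay on HEK293 cells for inhibition of transient receptor potential cation channel subfamily V member 1 (Homo sapiens), read by FLIPR, at pH 5.5 (on this read-out higher numbers stand for weaker inhibition and lower numbers for stronger inhibition), gives > 10000 nM.
Compound 2 `Cc1ccc(N2CCN(C(=O)Nc3ccc(C(F)(F)F)cc3)CC2)nn1` in this assay gives > 10000 nM.

Neither value is a number. For compound 1 the value > 10000 nM is a limit of this assay. For compound 2 the value > 10000 nM is likewise a limit. Compound 1 therefore stands at the limit of > 10000 nM in this assay, at which 2 of the 2 values shown sit, and no ranking among the measured compounds can be read from these figures.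

Compound 3 `O=C(Nc1nc2ccc(F)cc2s1)N1CCN(c2cccnn2)CC1` has not yet been measured in this assay. It differs from compound 1 by hydrogen in place of chloro on an aromatic carbon. For the measured compounds named here, no step between two measured compounds is available, so the size of the change cannot be drawn from the data. Compound 3 is expected to show a step that the limit leaves unreadable from compound 1 to compound 3, which amounts to no step beyond the scatter. The estimate for compound 3 in this assay is 20000 nM, with a range from 5000 nM to 80000 nM, and the result will most probably again be a limit.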

Compound 3, half-maximal inhibitory concentration: > 10000 nM
Compound 3 gave a limit, no number; the forecaster's own chance of this, stated with the estimate: 80%; the middle value lies beyond the limit too.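

For the compounds shown here, compound 1 and compound 3 both gave only a limit in this assay, so no step between them can be read. The compounds shown leave open whether hydrogen in place of chloro changes inhibition at all, with every value resting on the same limit: the limit of > 10000 nM in this assay, at which 3 of the 3 values shown sit.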